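From Fluorophenyl to Pyridyl on the Ring Nitrogen

The source may hold more compounds than are shown below. What is called first, only, known or untested is meant among the compounds shown, and "the series" means these compounds.

Compound 3 `Fc1ccc(N2CCN(Cn3nc(-c4ccc5c(c4)OCCO5)oc3=S)CC2)cc1` shares its core with compound 1 `S=c1oc(-c2ccc3c(c2)OCCO3)nn1CN1CCN(C(c2ccccc2)c2ccccc2)CC1` and compound 2 `S=c1oc(-c2ccc3c(c2)OCCO3)nn1CN1CCN(c2cccc(Cl)c2Cl)CC1`. In a functional assay on HeLa cells (Homo sapiens) for antiproliferative activity, read by MTT assay, with a stated time of 48 h (a lower number here means a stronger inhibitor, a higher number a weaker inhibitor), compound 1 gives > 50000 nM, which is a limit of the assay rather than a number. Compound 2 gives > 50000 nM in this assay, also a limit. Compound 3 gives > 50000 nM, again a limit. For the measured compounds named here, because all three sit at the limit of > 50000 nM in this assay, at which 3 of the 3 values shown sit, the one step between measured compounds, a step that the two limits leave unreadable from compound 2 to compound 3, cannot be read. Compound 4 `S=c1oc(-c2ccc3c(c2)OCCO3)nn1CN1CCN(c2ccccn2)CC1` differs from compound 3 in that (pyridin-2-yl in place of 4-fluorophenyl on an amine nitrogen in a ring). Going by the values given here, no measured step speaks to this change, and every value so far is a limit, so nothing argues for a stronger inhibitor. Compound 4 is therefore expected to give 60000 nM, within a range from 20000 nM to 200000 nM, meaning an expected step that the limit leaves unreadable from compound 3 to compound 4.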

Compound 4, half-maximal inhibitory concentration: 25100 nM
Compound 4: middle estimate off by 2.4-fold (0.38 log units), on the high side; low and high end bracket the measured number.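

Compound 4 is the only compound shown that gives a measured number rather than a limit in this assay, so the group on this amine nitrogen can move the read-out into the measurable range. Pyridin-2-yl gives an at least 1.9-fold lower number from compound 3 to compound 4 (0.29 log units; that floor lies within the scatter), and it gives an at least 1.9-fold lower number from compound 2 to compound 4 (0.29 log units; that floor lies within the scatter). The true size of both steps stays unknown, and the other compounds remain at a limit: the limit of > 50000 nM in this assay, at which 3 of the 4 values shown sit.

From the compounds shown here alone, it remains open whether the ring nitrogen of pyridin-2-yl accounts for the change. A plain phenyl or a pyridin-4-yl group at the same place would test this.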